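The source may hold more compounds than are shown below. What is called first, only, known or untested is meant among the compounds shown, and "the series" means these compounds.

Compound 1 `CN1CCN(c2nc3ccccc3[nH]2)CC1` gives > 3000 nM in a functional assay on ileum for inhibition of histamine H1 receptor (Cavia porcellus); on this read-out higher numbers stand for weaker inhibition and lower numbers for stronger inhibition — a limit of the assay, not a number.
Compound 2 `CCCn1c(N2CCN(C)CC2)nc2ccccc21` gives 380 nM in this assay.
Compound 3 `CCCSCn1c(N2CCN(C)CC2)nc2ccccc21` gives 68 nM in this assay.

Of the two numbers given, compound 3 stands lowest, with compound 2 nearest; compound 1 sits at the limit of > 3000 nM in this assay, at which 1 of the 3 values shown sits. The measured steps are an at least 7.8-fold lower number from compound 1 to compound 2 (0.89 log units; beyond the scatter), an at least 44-fold lower number from compound 1 to compound 3 (1.64 log units; beyond the scatter) and a 5.6-fold lower number from compound 2 to compound 3 (0.75 log units; beyond the scatter). Compound 4 `COCCn1c(N2CCN(C)CC2)nc2ccccc21` differs from compound 3 by methoxymethyl in place of propylsulfanyl on a saturated chain carbon bound to an aromatic nitrogen. The step that bears on this is the one in which propylsulfanyl entered in place of ethyl, a 5.6-fold lower number from compound 2 to compound 3 (0.75 log units; beyond the scatter), and the change to compound 4 runs in the reverse direction, though not the whole way back to the propyl of compound 2. A modest rise in this assay is therefore expected, with compound 4 staying between the values of compound 3 and compound 2; the expected step for compound 4 is a 3.2-fold higher number from compound 3 to compound 4 (0.51 log units; beyond the scatter). The estimate for compound 4 is 220 nM, with a range from 80 nM to 700 nM.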

Compound 4, half-maximal inhibitory concentration: 13 nM
Compound 4: the middle estimate sits 17-fold (1.23 log units) above what was measured; measured number outside the range, below it.
By their numbers in this assay, from the lowest: compound 4; then compound 3; then compound 2. At a limit, above all of these: compound 1.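

At this position on the aromatic nitrogen, the sulfur of (propylsulfanyl)methyl is not needed for a low number in this assay: 2-methoxyethyl, which carries oxygen in its place, gives a 5.2-fold lower number from compound 3 to compound 4 (0.72 log units; beyond the scatter). A single change on the propyl chain, methoxy in place of methyl, gives a 29-fold lower number from compound 2 to compound 4 (1.47 log units; beyond the scatter), so the outcome here does not follow the size of the group alone. The widest step, an at least 230-fold lower number from compound 1 to compound 4 (2.36 log units; beyond the scatter), starts from a value that is a limit and not a number: the limit of > 3000 nM in this assay, at which 1 of the 4 values shown sits.

On these data alone, whether a 2-hydroxyethyl or 2-aminoethyl chain, or a longer chain such as 3-methoxypropyl, would hold this low number remains open. The compounds shown also do not tell why the oxygen-bearing chain gives the lowest number of the series.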